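Series notes: distal phenyl substitution, compound 3 to compound 4

The compounds below may be only part of what the source reports. "The series", "measured", "known", "first", "only" and "open" are said of these compounds alone.

Measured so far:
compound 1 `CC[C@H](C)[C@H](N)CN(C(=O)[C@@H]1C[C@H]1c1ncccn1)c1ccc(-c2ccccc2)cc1`, 130 nM
compound 2 `CC[C@H](C)[C@H](N)CN(C(=O)[C@@H]1C[C@H]1c1cncnc1)c1ccc(-c2ccccc2)cc1`, 19000 nM
compound 3 `CCOc1ccc(-c2ccc(N(C[C@@H](N)[C@@H](C)CC)C(=O)[C@@H]3C[C@H]3c3ccccc3)cc2)cc1`, 90 nM

In a functional assay for agonist activity at G protein-coupled receptor 88 (Homo sapiens), read by HTRF and cAMP accumulation (a lower number here means that less compound is needed, a higher number that more compound is needed for the effect), compound 3 holds the lowest of the three numbers; its gap to compound 1 lies within the scatter, while compound 2 sits far higher. Going by the values given here, the only step measured in one place, a 150-fold higher number from compound 1 to compound 2 (2.16 log units; beyond the scatter), concerns the ring on the saturated carbon and does not touch the distal phenyl. Compound 4 `CC[C@H](C)[C@H](N)CN(C(=O)[C@@H]1C[C@H]1c1ccccc1)c1ccc(-c2ccc(CN(C)C)cc2)cc1` differs from compound 3 by (dimethylamino)methyl in place of ethoxy on an aromatic carbon. Among the compounds with values here, no measured step bears on this change, so the expectation rests on compound 3 alone: a step of a 1.7-fold higher number from compound 3 to compound 4 (0.22 log units; within the scatter) is expected, with no direction beyond the scatter favored. Compound 4 is therefore estimated at 150 nM, between 40 nM and 600 nM.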

Compound 4, half-maximal effective concentration: 460 nM
Compound 4: the middle estimate sits 3.1-fold (0.49 log units) below what was measured; the measured number falls inside the stated range.
By their numbers in this assay, from the lowest: compounds 3 and 1 (each within the scatter of the next); then compound 4; then compound 2.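

Going by these compounds alone, with a 5.1-fold higher number from compound 3 to compound 4 (0.71 log units; beyond the scatter) in this assay, the aromatic carbon para to a large group responds to the exchange of ethoxy for (dimethylamino)methyl, the first reading at this place. The two groups have the same hydrogen-bond donor and acceptor counts and no net charge, so these counts do not separate them. No supporting evidence accounts for the step.

From the compounds shown here alone, whether the step follows from losing ethoxy or from gaining (dimethylamino)methyl stays open. A longer ether chain, a primary amine or a carboxylic acid on this carbon would help to separate the two readings.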